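A Carbamoyl Extension on Compound 2

The source may report more compounds than this note shows. Statements on the series, on what has been measured and on what is new or still open speak of the compounds shown alone.

Compound 1 `Cc1ccc(C(=O)Nc2ccc(Cl)cc2C(N)=O)cc1` in a functional assay on MCF7 cells (Homo sapiens) for antiproliferative activity, read by MTT assay, with a stated time of 48 h (a higher number here means a weaker inhibitor, a lower number a stronger inhibitor), gives 5.39 ug/mL
Compound 2 `CSc1nc(-c2ccc(C)cc2)nc2ccc(Cl)cc12` in this assay gives 8.64 ug/mL

The values of compound 1 and compound 2 lie within the usual scatter of each other, and neither can be ranked. Compound 3 `Cc1ccc(NC(=O)CSc2nc(-c3ccc(C)cc3)nc3ccc(Cl)cc23)cc1` differs from compound 2 by (4-methylphenyl)carbamoyl in place of hydrogen on a saturated chain carbon bound to a sulfur in one place, (4-methylphenyl)carbamoyl in place of hydrogen on a saturated chain carbon bound to a sulfur. For the measured compounds named here, no measured pair shows a change of this kind, so the expectation is loose. A modest step toward stronger inhibition is expected in this assay for this change, and a 1.9-fold lower number from compound 2 to compound 3 (0.28 log units; within the scatter) is the estimated step here. The estimated value for compound 3 is 4.5 ug/mL with an expected range from 1.5 ug/mL to 14 ug/mL in this measurement.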

Compound 3, half-maximal inhibitory concentration: 5.79 ug/mL
For compound 3 the middle estimate is 1.3-fold (0.11 log units) below the measured one; measured number inside the range.
By their numbers in this assay, from the lowest: compounds 1, 3 and 2 (each within the scatter of the next).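

In this assay, for the compounds shown here, the swap of hydrogen for (4-methylphenyl)carbamoyl on the saturated chain carbon bound to a sulfur gives a 1.5-fold lower number from compound 2 to compound 3 (0.17 log units; within the scatter) and is the first measured step at this position. Even with 10 heavy atoms entering there, compound 3 cannot be told apart from compound 2, so this carbon tolerates the added group in this read-out. No measurement here accounts for this result. As far as these compounds go, whether an amine or a carboxylic acid on the same carbon would also leave the number within the scatter stays open. So does the effect of a longer chain between the sulfur and the carbonyl.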